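Ethyl position on the aryl amine of the core

The compounds below may be only part of what the source reports. "The series", "measured", "known", "first", "only" and "open" are said of these compounds alone.

The series shares the core of compound 1 `CCc1ccc(Nc2cc(NC(=O)Nc3cc(OC)cc(OC)c3)ncn2)cc1` with varied aryl groups on its two nitrogens. In a functional assay on PC-9 cells (Homo sapiens) for inhibition, read by MTT assay, with a stated time of 48 h, tested at 10 uM (a lower number here means less inhibition, a higher number more inhibition at the concentration tested (going by the name of the read-out)), compound 1 gives 78%. Compound 2 `COc1ccc(F)cc1Nc1cc(NC(=O)Nc2c(Cl)cccc2Cl)ncn1` gives 85.5% and compound 3 `Cc1cc(F)cc(Nc2cc(NC(=O)Nc3c(Cl)cccc3Cl)ncn2)c1` gives 80%. Compound 1 holds the lowest of the three numbers, yet both gaps lie within the scatter, so no order among compounds 1, 2 and 3 can be read from them.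

Compound 4 `CCc1cccc(Nc2cc(NC(=O)Nc3cc(OC)cc(OC)c3)ncn2)c1` differs from compound 1 only in the aryl group on the nitrogen on an aromatic ring: 3-ethylphenyl in place of 4-ethylphenyl on a nitrogen on an aromatic ring. Among the measured compounds shown here, the single measured step, a number 5.5 percentage points lower from compound 2 to compound 3 (within the scatter), changes the aryl group on that same nitrogen, and it stayed within the scatter. For the measured compounds named here, no measured step moves an ethyl group within a phenyl ring, so that step gives only indirect support. On this basis compound 4 is expected to stay close to compound 1, with a number 2 percentage points lower from compound 1 to compound 4 (within the scatter) as the estimated step, not beyond the scatter. Compound 4 is therefore estimated at 76%, within a range of 62% to 88%.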

Compound 4, a percentage reported as inhibition, at one concentration (the size of the read-out at that concentration, not a potency): 82.1%
For compound 4 the middle estimate is 6.1 percentage points below the measured one; low and high end bracket the measured number.
By their numbers in this assay, from the lowest: compounds 1, 3, 4 and 2 (each within the scatter of the next).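

In this assay, among the compounds shown here, the ethyl group itself moves for the first time, with the atoms unchanged, and the result is a number 4.1 percentage points higher from compound 1 to compound 4 (within the scatter) and so no separation between 4-ethylphenyl and 3-ethylphenyl on this nitrogen. The earlier step changed the whole aryl group, whereas this one shows that ethyl placement on the ring, taken alone, leaves the read-out within the scatter at the single concentration tested. Nothing at hand speaks to the reason for this result.

Whether the ethyl group matters at all remains open, since neither a longer chain such as butyl nor a polar group such as an amine or a carboxylic acid appears in its place among these compounds. Also open, from the compounds shown here alone, is whether the same move would read alike with the aryl group of compounds 2 and 3 on the other nitrogen, and whether full potency values would separate the two placements.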